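Pyridyl for Methoxyphenyl on the Shared Core

This account rests on a few compounds, and the source may have more. Where it says the series, first, only, none or still open, it means among the compounds named here.

Two compounds of the series have numbers in an assay on CHO cells for displacement of a labelled ligand from adenosine receptor A3 (Homo sapiens), read by scintillation counting, with a stated time of 3 h; on this read-out higher numbers stand for weaker inhibition and lower numbers for stronger inhibition. Compound 1 `COc1ccc(-c2nc3c(NC4CCCC4)ncnc3n2C)cc1` gives 1850 nM and stands lowest of the two; its nearest neighbour is compound 2 `Cn1c(-c2ccc(C(=O)O)cc2)nc2c(NC3CCCC3)ncnc21`, which in this assay gives 25700 nM. Among the measured compounds shown here, the single measured step, a 14-fold higher number from compound 1 to compound 2 (1.14 log units; beyond the scatter), is a change of the group on the pendant aromatic ring, not of the ring itself.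

Compound 3 `Cn1c(-c2cccnc2)nc2c(NC3CCCC3)ncnc21` has not been measured. It differs from compound 1 in one place: pyridin-3-yl in place of 4-methoxyphenyl on an aromatic carbon. For the measured compounds named here, no measured step covers an exchange of the whole pendant ring, so the step from compound 1 to compound 2 bears on it only loosely; it shows that changes at this position can move the number by a large amount. The expected outcome is a moderate rise in this assay, a 2.4-fold higher number from compound 1 to compound 3 (0.39 log units; beyond the scatter), giving for compound 3 an estimated 4500 nM with a range from 1200 nM to 17000 nM.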

Compound 3, inhibition constant: 11000 nM
Beside the measured number, compound 3's estimate is 2.4-fold (0.39 log units) below it, and the stated range covers the measured number.
By their numbers in this assay, from the lowest: compound 1; then compound 3; then compound 2.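

In this assay, exchange of the whole pendant ring at the aromatic carbon between two ring nitrogen atoms now has a measured step of its own, a 5.9-fold higher number from compound 1 to compound 3 (0.77 log units; beyond the scatter), so the number at this position moves with the ring as well as with the group it carries. Compound 1 remains the lowest of the three, and both changes away from 4-methoxyphenyl shown so far raise the number, with compound 3 at 11000 nM under compound 2 at 25700 nM. Nothing available accounts for the rise seen with pyridin-3-yl.

This step swaps the ring nitrogen in and the methoxy out together, and unsubstituted phenyl would separate the two. As far as these compounds go, it also remains open whether an amine or a longer alkoxy chain in place of methoxy would bring the number below that of compound 1.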